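This account rests on a few compounds, and the source may have more. Where it says the series, first, only, none or still open, it means among the compounds named here.

Working notes on a small selenium-bearing series. Compound 2 `O=C(/N=C(/NC(=O)c1ccco1)[Se]Cc1ccccc1)c1ccco1` carries a benzyl group on the selenium; in a functional assay on PC-3 cells (Homo sapiens) for cytotoxicity, read by MTT assay, with a stated time of 72 h (a lower number here means that less compound is tolerated, a higher number that more compound is tolerated), compound 2 gives 84800 nM. Compound 1 `C[Se]/C(=N\C(=O)c1ccco1)NC(=O)c1ccco1` differs from it by hydrogen in place of phenyl on a saturated chain carbon bound to a selenium atom. In this assay compound 1 reaches only a limit of the assay, > 100000 nM. The step of an at least 1.1-fold higher number from compound 2 to compound 1 (0.07 log units; that floor lies within the scatter) can be sized no further than a floor because the limit of > 100000 nM in this assay, at which 2 of the 3 values shown sit, holds compound 1. Compound 3 `O=C(/N=C(/NC(=O)c1csc([N+](=O)[O-])c1)[Se]Cc1ccccc1)c1csc([N+](=O)[O-])c1` rests on a different core; how that core differs from compound 2 is not broken down here. In this assay compound 3 likewise sits at a limit of the assay, > 100000 nM. Compound 4 `C[Se]/C(=N\C(=O)c1csc([N+](=O)[O-])c1)NC(=O)c1csc([N+](=O)[O-])c1` differs from compound 3 by hydrogen in place of phenyl on a saturated chain carbon bound to a selenium atom, the same change as from compound 2 to compound 1. The step that the limit leaves unreadable from compound 3 to compound 4 is expected to remain unresolved because the limit of > 100000 nM in this assay, at which 2 of the 3 values shown sit, already holds compound 3. Compound 4 is estimated at 150000 nM, most likely reported again as a limit.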

Compound 4, concentration lethal to 50% of the cells: > 100000 nM
Compound 4: only a limit was reported; the forecaster's own chance of this, stated with the estimate: 85%; the middle value does not contradict the limit.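

No step can be read from compound 3 to compound 4, since each of the two stands only at a limit of the assay: the limit of > 100000 nM in this assay, at which 3 of the 4 values shown sit.

What benzyl to methyl does on the core of compound 3 stays open in the compounds shown.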